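The compounds below may be only part of what the source reports. "The series", "measured", "known", "first", "only" and "open" are said of these compounds alone.

Measured in an ADME assay on microsomes from liver (Homo sapiens) for metabolic stability, read by LC-MS, using NADPH, with a stated time of 60 min, tested at 0.1 uM; a lower number here means that less of the compound is left, a higher number that more of the compound is left:
- Compound 1 `Fc1ccc(Nc2cc3[nH]c(Nc4ccc(N5CCNCC5)cn4)nc3cn2)cc1C(F)(F)F`: 92%
- Compound 2 `Fc1ccc(Nc2cc3[nH]c(Nc4ccc(N5CCN(CC6CC6)CC5)cn4)nc3cn2)cc1C(F)(F)F`: 52%
- Compound 3 `C[C@@H]1CN(c2ccc(Nc3nc4cnc(Nc5ccc(F)c(C(F)(F)F)c5)cc4[nH]3)nc2)C[C@H](C)O1`: 17%

Compound 2, with 52%, stands second highest of these three. It is separated from the others by a number 40 percentage points lower from compound 1 to compound 2 (beyond the scatter) and by a number 35 percentage points lower from compound 2 to compound 3 (beyond the scatter).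

Compound 4 `FC1(F)CC(Nc2cc3[nH]c(Nc4ccc(N5CCN(CC6CC6)CC5)cn4)nc3cn2)C1` keeps the 4-(cyclopropylmethyl)piperazin-1-yl group of compound 2 and changes a different group: 3,3-difluorocyclobutyl in place of 4-fluoro-3-(trifluoromethyl)phenyl on a nitrogen on an aromatic ring. In words, 3,3-difluorocyclobutyl takes the place of 4-fluoro-3-(trifluoromethyl)phenyl on a nitrogen on an aromatic ring.

Within the data shown here, no measured step changes this group, so none bears on it directly. All three steps change the group on the other aromatic carbon, and the largest is a number 75 percentage points lower from compound 1 to compound 3 (beyond the scatter). Among the measured compounds shown here, they show only that a single change can move the read-out a long way, and they give no direction for the new change. The starting point therefore remains compound 2 at 52%, with only a slight rise expected and no step beyond the scatter as the best guess. The expected change is a number 8 percentage points higher from compound 2 to compound 4 (within the scatter). For compound 4 the estimated value is 60%, with an expected range of 35% to 85%.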

Compound 4, percent of the compound remaining: 86%
The estimate for compound 4 lay 26 percentage points below the measured number; measured number above the stated range.
By their numbers in this assay, from the lowest: compound 3; then compound 2; then compounds 4 and 1 (each within the scatter of the next).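

In this assay, putting 3,3-difluorocyclobutyl in place of 4-fluoro-3-(trifluoromethyl)phenyl on a nitrogen on an aromatic ring gives a number 34 percentage points higher from compound 2 to compound 4 (beyond the scatter). Among these compounds, the earlier steps changed only the group on the other aromatic carbon, so this is the first sign that the group on this nitrogen can also move the read-out by a large amount, here with the 4-(cyclopropylmethyl)piperazin-1-yl group held constant. Nothing available here explains why the read-out rises with this change.

This single swap alters several things at once: 11 heavy atoms become 6, a six-membered aromatic ring of carbon becomes a four-membered non-aromatic ring, and 4 fluorine atoms become 2, so the compounds shown cannot separate these differences. As far as these compounds go, it remains open whether a plain cyclobutyl group without fluorine, or an unsubstituted phenyl group, would give a read-out nearer to compound 2 or to compound 4, and whether the 3,3-difluorocyclobutyl change would have a similar effect alongside the 2,6-dimethylmorpholin-4-yl group of compound 3.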